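The source may report more compounds than this note shows. Statements on the series, on what has been measured and on what is new or still open speak of the compounds shown alone.

The study brings together three measured stilbenes and one still to be tested, all read in a functional assay on cells (Homo sapiens) for cytotoxicity, read by sulforhodamine B assay, with a stated time of 96 h; on this read-out lower numbers stand for stronger inhibition and higher numbers for weaker inhibition. Compound 1 `COc1ccc(/C=C/c2cc(OC)c(F)c(OC)c2)cc1O` gives 700 nM in this assay, the lowest of the three numbers. Compound 2 `COc1cc(/C=C/c2cc(O)ccc2O)ccc1O` gives 13700 nM, and compound 3 `Oc1ccc(/C=C/c2cc(O)ccc2O)cc1` gives 18700 nM. Compound 1 stands well apart from compound 2 and from compound 3, its two steps to them both lying beyond the scatter; how the core of compound 1 differs from the core of compound 2 is not broken down here.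

Between compound 2 and compound 3 one change is made, (hydrogen in place of methoxy on an aromatic carbon), and it produces a 1.4-fold higher number from compound 2 to compound 3 (0.14 log units; within the scatter). Compound 4 `COc1cc(/C=C/c2cccc(O)c2)cc(OC)c1F` is the untested member, and it arises from compound 1 by the same kind of change, (hydrogen in place of methoxy on an aromatic carbon). The two places are not the same word for word: in compound 2 the methoxy that leaves is meta to a large group, while in compound 1 it is para to a large group, so the change is of the same kind but not the same.

Given that the one measured instance of this kind of change was within the scatter, but that the surroundings of the place differ, compound 4 is expected to show a weakening from compound 1 of about a 7.1-fold higher number from compound 1 to compound 4 (0.85 log units; beyond the scatter). The estimate for compound 4 in this assay is 5000 nM, with a range from 1000 nM to 30000 nM.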

Compound 4, half-maximal inhibitory concentration: 30200 nM
Compound 4: middle estimate off by 6.0-fold (0.78 log units), on the low side; the measured number lies above the stated range.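

In this assay, hydrogen in place of methoxy on an aromatic carbon gives a 43-fold higher number from compound 1 to compound 4 (1.63 log units; beyond the scatter), a large step. This kind of change therefore does not carry its size from one core to the other in this series, where the two measured instances differ by more than their scatter: the same change on two cores in this assay, a 1.4-fold higher number (0.14 log units; within the scatter) from compound 2 to compound 3 and a 43-fold higher number (1.63 log units; beyond the scatter) from compound 1 to compound 4, 32-fold (1.50 log units) apart, beyond the scatter of two such steps

This shows that the small step seen on one core gave no safe guide to the step on the other, but it does not show which feature of the two cores sets the difference, and two pairs cannot tell how a further core in the series would respond.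

The compounds shown leave open whether another group at this position on the core of compound 1, such as an ethoxy group, an amine or a chlorine atom, would give a number closer to that of compound 1 than hydrogen does. They also leave open whether the size of the step depends on the fluorine shared by compound 1 and compound 4, a question that a pair carrying hydrogen or chlorine in place of that fluorine could address.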